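The source may hold more compounds than are shown below. What is called first, only, known or untested is meant among the compounds shown, and "the series" means these compounds.

Measured compounds in a functional assay on NCI-H23 cells (Homo sapiens) for inhibition, read by sulforhodamine B assay; on this read-out lower numbers stand for stronger inhibition of growth and higher numbers for weaker inhibition of growth:

- compound 1, `Cc1ccccc1CN1CC=C(CCC(=O)NO)C1=O`, gives 2500 nM
- compound 2, `O=C(CCC1=CCN(CCCc2ccc(Br)cc2)C1=O)NO`, gives 2520 nM

For the measured compounds named here, only two compounds carry numbers so far, and no pair among them differs in one place, so no single-change step can be drawn. Compound 2 and compound 1 sit essentially on the same number in this assay: the gap between them lies within the scatter of repeated measurements, so the two cannot be told apart on this read-out, and nothing can be said about whether the benzyl or the arylpropyl arrangement matters for growth inhibition.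

The next compound, compound 3, `CCOc1ccc(CCCN2CC=C(CCC(=O)NO)C2=O)cc1`, is not yet measured. It keeps the whole of compound 2 apart from one change on the aromatic ring:

ethoxy in place of bromo on an aromatic carbon

Going by the values given here, with no measured step of any kind to lean on, the working expectation is that this exchange of a single substituent moves the number by no more than the scatter, in either direction. The estimated step of a 1.2-fold higher number from compound 2 to compound 3 (0.08 log units; within the scatter) is therefore set close to none. For compound 3 the estimate in this assay is 3000 nM, with a range from 1200 nM to 7500 nM.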

Compound 3, concentration for 50% growth inhibition: 2520 nM
Compound 3: middle estimate off by 1.2-fold (0.08 log units), on the high side, within the range that was stated.
By their numbers in this assay, from the lowest: compounds 1, 2 and 3 (each within the scatter of the next).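

In this assay, for the compounds shown here, the exchange of bromo for ethoxy on an aromatic carbon, para to a large group, gives no change at the digits printed from compound 2 to compound 3 (within the scatter) and provides the first single-change step. For this pair, a single bromine and an ethoxy group of 3 heavy atoms with 1 hydrogen-bond acceptor cannot be told apart on this read-out, so this one position tolerates this exchange with no difference that can be resolved. No measurement among those shown explains why the two substituents read alike.

From the compounds shown here alone, it remains open whether this position would read the same with an amine, a carboxylic acid or a longer chain such as butoxy, since one exchange does not describe the position's tolerance for other groups. Also open, going by these compounds, is whether the flat reading extends beyond this aromatic position, for example to replacing the hydroxamic acid with a carboxylic acid or to shortening or lengthening the chain that joins the aromatic ring to the shared core.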